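A few compounds are considered here, and "the series" means these few. Any claim that something is new, unique, unknown or untested is made for them only; others in the source may bear on it.

For the measured compounds named here, in an ADME assay on CCRF-CEM cells (Homo sapiens) for cytotoxicity, with a stated time of 72 h (on this read-out lower numbers stand for stronger inhibition and higher numbers for weaker inhibition), compound 2 `O=Cc1c(-c2ccc(Cl)cc2Cl)nc2sc(Cc3ccc(Cl)cc3)nn12` gives 79000 nM, the only number among the values shown. Compound 1 `Clc1ccc(Cc2nn3c(Br)c(-c4ccccc4)nc3s2)cc1` reaches only the assay limit of > 250000 nM in this assay. Compound 3 `O=Cc1c(-c2ccccc2)nc2sc(Cc3ccc(Cl)cc3)nn12` differs from compound 2 by phenyl in place of 2,4-dichlorophenyl on an aromatic carbon. Going by the values given here, no measured pair shares this change, so its size is not known from the data. Compound 1, which also carries phenyl on its core, sits at the limit of > 250000 nM in this assay, at which 1 of the 2 values shown sits, so the change is expected to weaken rather than strengthen inhibition, by an estimated step of a 2.0-fold higher number from compound 2 to compound 3 (0.31 log units; beyond the scatter). Compound 3 is accordingly estimated at 160000 nM in this assay, between 50000 nM and 400000 nM.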

Compound 3, half-maximal inhibitory concentration: 22000 nM
Beside the measured number, compound 3's estimate is 7.3-fold (0.86 log units) above it, outside the stated range (below it).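

In this assay, phenyl in place of 2,4-dichlorophenyl on this aromatic carbon strengthens inhibition rather than weakening it: a 3.6-fold lower number from compound 2 to compound 3 (0.56 log units; beyond the scatter). A second change on the core also counts, with formyl in place of bromo on an aromatic carbon giving an at least 11-fold lower number from compound 1 to compound 3 (1.05 log units; beyond the scatter). The value of compound 1, > 250000 nM, is a limit of the assay.

The compounds shown leave open whether a single chlorine on the phenyl ring would already raise the number, and whether an amine or a carboxylic acid in place of the formyl group would keep the inhibition of compound 3.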